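Notes on the step from compound 3 to compound 4

This account rests on a few compounds, and the source may have more. Where it says the series, first, only, none or still open, it means among the compounds named here.

All compounds here share one core, which carries two 4-methoxyphenyl groups, and differ in a single group on an aromatic carbon. In a functional assay with Oryctolagus cuniculus as the target (on this read-out lower numbers stand for stronger inhibition and higher numbers for weaker inhibition), compound 3 `COc1ccc(-c2nc(C(=O)N=C(N)N)sc2-c2ccc(OC)cc2)cc1` gives > 100 nM, which is a limit and not a number. Compound 1 `COc1ccc(-c2nc(/N=C(\N)[N+]3(C)CCCCC3)sc2-c2ccc(OC)cc2)cc1` gives > 1000 nM in this assay, also a limit. Among the compounds with values here, compound 2 `COc1ccc(-c2nc(CNC(=O)NC(C)C)sc2-c2ccc(OC)cc2)cc1` gives 42 nM in this assay, the only true number so far.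

The unmeasured compound 4 `COc1ccc(-c2nc(CCC(=O)O)sc2-c2ccc(OC)cc2)cc1` follows from compound 3 by this change: a group of 5 heavy atoms (3 carbon, 2 oxygen; no ring) in place of a group of 6 heavy atoms (2 carbon, 3 nitrogen, 1 oxygen; no ring), on an aromatic carbon. Within the data shown here, the entering 2-carboxyethyl group has no counterpart among the measured compounds.

Three measured steps change the same site. The step of an at least 23-fold lower number from compound 1 to compound 2 (1.37 log units; beyond the scatter) is large, the step of an at least 2.3-fold higher number from compound 2 to compound 3 (0.37 log units; beyond the scatter) is at least modest, and the step that the two limits leave unreadable from compound 1 to compound 3 cannot be read. Changes here can therefore move the read-out beyond the scatter, but none of these steps gives a size for this change. With only a limit for compound 3, no direction can be firmly assigned in this assay, and only a small step is expected. The estimated step runs a step that the limit leaves unreadable from compound 3 to compound 4. Compound 2, at 42 nM, remains the expected better end of the series. For compound 4 the estimated value is 150 nM, with an expected range of 30 nM to 1000 nM.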

Compound 4, half-maximal inhibitory concentration: < 100 nM
Compound 4 gave a limit, no number (the forecaster's own chance of this, stated with the estimate: 40%); middle value at least 1.5-fold (0.17 log units) from the limit.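

Of the compounds shown, compound 4 alone carries no nitrogen in the group on this aromatic carbon, and its result in this assay is a limit: the limit of < 100 nM in this assay, at which 1 of the 4 values shown sits. Replacing the group of compound 3 with 2-carboxyethyl gives a number no higher from compound 3 to compound 4 (the limit leaves the size open), so the two limits now fix a direction for this change, which the estimate could not do beforehand. The same group also gives an at least 10-fold lower number from compound 1 to compound 4 (1.00 log units; beyond the scatter), which shows that a nitrogen-free chain with no ring on this carbon is compatible with a read-out well clear of the limit of compound 1, though no cause for this can be drawn from the compounds shown.

Going by these compounds, the step from compound 2 to compound 4 cannot be read, so the order of these two compounds, the only ones on the low side of the read-out, stays open. Also open, on these data alone, is whether the carboxylic acid itself matters, which the methyl ester or primary amide of the same chain would test, and how the read-out responds to a longer chain or to an amine at the chain end.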